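Benzyl in Place of Cyclohexyl in a Dihydropyridine Ester

The source may hold more compounds than are shown below. What is called first, only, known or untested is meant among the compounds shown, and "the series" means these compounds.

Compound 1 `CCOC(=O)C1=C(C)NC(C)=C(C(=O)OCC)C1c1[nH]cnc1Cl`: 437 nM in an assay on isolated protein for inhibition of Voltage-dependent L-type calcium channel subunit alpha-1C (Cavia porcellus); a lower number here means a stronger inhibitor, a higher number a weaker inhibitor
Compound 2 `CCOC(=O)C1=C(C)NC(C)=C(C(=O)OC(C)(C)C)C1c1[nH]cnc1Cl`: 1660 nM
Compound 3 `CCOC(=O)C1=C(C)NC(C)=C(C(=O)OCC2CCCCC2)C1c1[nH]cnc1Cl`: 513 nM

All three share one core and differ only on a saturated chain carbon bound to an oxygen next to a carbonyl group, or on that oxygen itself. Compound 3 sits close to compound 1, the two numbers lying within the usual scatter, while the step of a 3.2-fold lower number from compound 2 to compound 3 (0.51 log units; beyond the scatter) is a modest gain. Compound 4 `CCOC(=O)C1=C(C)NC(C)=C(C(=O)OCCc2ccccc2)C1c1[nH]cnc1Cl` carries the change (benzyl in place of cyclohexyl on a saturated chain carbon bound to an oxygen next to a carbonyl group). The steps that touch the same position are a 3.8-fold higher number from compound 1 to compound 2 (0.58 log units; beyond the scatter) and a 1.2-fold higher number from compound 1 to compound 3 (0.07 log units; within the scatter): one moved the number modestly, the other stayed within the scatter. Among the compounds with values here, no measured compound tests an aromatic ring at this place, so the step of a 1.1-fold lower number from compound 3 to compound 4 (0.06 log units; within the scatter) is expected to be small, with no direction beyond the scatter claimed. Compound 4 is therefore estimated at 450 nM, with a range of 150 nM to 1400 nM.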

Compound 4, half-maximal inhibitory concentration: 70.8 nM
For compound 4 the middle estimate is 6.4-fold (0.80 log units) above the measured one; the whole stated range lies above it.
By their numbers in this assay, from the lowest: compound 4; then compounds 1 and 3 (each within the scatter of the next); then compound 2.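

Benzyl in place of cyclohexyl gives a 7.2-fold lower number from compound 3 to compound 4 (0.86 log units; beyond the scatter) with only that group changed, so this position can respond strongly, even though a 1.2-fold higher number from compound 1 to compound 3 (0.07 log units; within the scatter) gave no sign of it. Phenyl in place of hydrogen gives a 6.2-fold lower number from compound 1 to compound 4 (0.79 log units; beyond the scatter) and phenethyl in place of tert-butyl gives a 23-fold lower number from compound 2 to compound 4 (1.37 log units; beyond the scatter) and so, among these four compounds, only the one with an aromatic ring here has a clearly lower number. Nothing available explains this gain. Open, on these data alone, is whether a longer chain such as phenylpropyl, or a pyridine ring in place of the phenyl, would keep it.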